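This account rests on a few compounds, and the source may have more. Where it says the series, first, only, none or still open, it means among the compounds named here.

Compound 1 `O=C(CCn1cnc2cc(-c3noc(CCC4CCCC4)n3)ccc21)N1CCOCC1`: > 20000 nM
Compound 2 `O=C(CCn1cnc2cc(-c3noc(CCC4CCCC4)n3)ccc21)NC1CCCCC1`: > 20000 nM

Two amides built on the same core were tested in a toxicity assay on HepG2 2.2.15 cells (Homo sapiens) for cytotoxicity, read by CCK-8 assay, with a stated time of 72 h; on this read-out lower numbers stand for higher toxicity in this test and higher numbers for lower toxicity in this test. Compound 1 `O=C(CCn1cnc2cc(-c3noc(CCC4CCCC4)n3)ccc21)N1CCOCC1` reached only a limit of the assay in this assay, giving > 20000 nM. Compound 2 `O=C(CCn1cnc2cc(-c3noc(CCC4CCCC4)n3)ccc21)NC1CCCCC1` likewise stopped at a limit there, with > 20000 nM. Within the data shown here, the one measured step, a step that the two limits leave unreadable from compound 1 to compound 2, therefore cannot be read. Both values sit at the limit of > 20000 nM in this assay, at which 2 of the 2 values shown sit. Compound 2 thus stands at the limit of this assay, with nothing in the numbers that sets it apart from compound 1.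

Compound 3 `O=C(CCn1cnc2cc(-c3noc(CCC4CCCC4)n3)ccc21)N1CCCC1` differs from compound 2 by pyrrolidin-1-yl in place of cyclohexylamino on a carbonyl carbon. Among the measured compounds shown here, the only measured step, a step that the two limits leave unreadable from compound 1 to compound 2, also exchanged the group on the carbonyl carbon, and it bears on this change only in that neither end of it gave a number. No readable step exists from which a size or a direction could be taken. Compound 3 is therefore expected to stay at the limit in this assay, and the step that the limit leaves unreadable from compound 2 to compound 3 is estimated to lie within the scatter. The estimate for compound 3 is 25000 nM, with a range from 10000 nM to 80000 nM.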

Compound 3, half-maximal cytotoxic concentration: > 20000 nM
Compound 3: a limit, no number; the forecaster's own chance of this, stated with the estimate: 80%; the middle value does not contradict the limit.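

Compound 3 also stopped at a limit in this assay, as did compound 1 and compound 2, so no step among these three compounds can be read: the limit of > 20000 nM in this assay, at which 3 of the 3 values shown sit.

The compounds shown leave open whether any group on the carbonyl carbon of the shared core would give a measurable number in this assay.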